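The compounds below may be only part of what the source reports. "The series", "measured", "known", "first", "only" and "open" are said of these compounds alone.

Measured so far:

Compound 1, `CCO[C@H]1C[C@@H](c2coc3ccccc3c2=O)N(c2ccccc2)O1`. In a functional assay on PC-3 cells (Homo sapiens) for inhibition, read by sulforhodamine B assay, with a stated time of 48 h (a higher number here means a weaker inhibitor, a lower number a stronger inhibitor), compound 1 reaches only a limit of the assay, > 60000 nM.
Compound 2, `CCO[C@H]1C[C@@H](c2coc3ccc(F)cc3c2=O)N(c2ccccc2)O1`. In this assay compound 2 gives 31700 nM.
Compound 3, `CCO[C@H]1C[C@@H](c2coc3ccc(C)cc3c2=O)N(c2ccccc2)O1`. In this assay compound 3 gives 39000 nM.

Compound 3 carries the higher of the two numbers that were read, but its distance to compound 2 is small, a 1.2-fold higher number from compound 2 to compound 3 (0.09 log units; within the scatter), so the two cannot be ordered. Compound 1 stands apart only as a limit. The steps from compound 1 to the two substituted analogues, an at least 1.8-fold lower number from compound 1 to compound 2 (0.27 log units; that floor lies within the scatter) and an at least 1.5-fold lower number from compound 1 to compound 3 (0.18 log units; that floor lies within the scatter), both have floors inside the scatter and both touch the aromatic ring.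

Compound 4, `Cc1ccc2occ([C@@H]3C[C@H](OCC(C)C)ON3c3ccccc3)c(=O)c2c1`, differs from compound 3 at a different place: isopropyl in place of methyl on a saturated chain carbon bound to an oxygen on a saturated carbon. For the measured compounds named here, none of the measured steps alters this chain, so they give no direction for the change; they only show that all three compounds sit in a narrow, weak band. The expectation is therefore a step that stays within the scatter, a 1.0-fold higher number from compound 3 to compound 4 (0.01 log units; within the scatter). For compound 4 the estimated value in this assay is 40000 nM, with a range from 15000 nM to 100000 nM.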

Compound 4, half-maximal inhibitory concentration: 37700 nM
For compound 4 the middle estimate is 1.1-fold (0.03 log units) above the measured one, and the stated range covers the measured number.
By their numbers in this assay, from the lowest: compounds 2, 4 and 3 (each within the scatter of the next). At a limit, above all of these: compound 1.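

Swapping methyl for isopropyl on a saturated chain carbon bound to an oxygen on a saturated carbon, the same difference as ethoxy to isobutoxy, gives a 1.0-fold lower number from compound 3 to compound 4 (0.01 log units; within the scatter) in this assay. This is the only step shown that touches this chain, since the earlier steps all changed a group on an aromatic carbon, and it shows that three heavy atoms in place of one leave the number unmoved beyond the scatter. Compound 4 therefore sits with compound 2 and compound 3 in one weak band, although this rests on a single pair that carries methyl on the aromatic ring.

The compounds shown leave open whether another group at this place, such as an amine, a carboxylic acid or a longer chain, would take the number out of this band, and whether the isobutoxy chain would read the same with fluoro or hydrogen on the aromatic ring. How far the ring substituents lower the number from compound 1 also stays unsized, as compound 1 gives only a limit: the limit of > 60000 nM in this assay, at which 1 of the 4 values shown sits.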